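Changing the Amide Aryl Group from Compound 2 to Compound 4

The source may report more compounds than this note shows. Statements on the series, on what has been measured and on what is new or still open speak of the compounds shown alone.

In an assay on MDA-MB-231 cells for binding affinity to C-X-C chemokine receptor type 4 (Homo sapiens), read by immunofluorescence and microscopy, with stated times of 10 min and 30 min (a higher number here means that more compound is needed for the effect, a lower number that less compound is needed), the measured compounds read as follows. Compound 1 `Cc1ccc(C(=O)NCc2ccc(CNS(=O)(=O)c3ccc(C)cc3)cc2)cc1` gives 1000 nM. Compound 2 `O=C(NCc1ccc(CNS(=O)(=O)c2ccccc2)cc1)c1ccccc1Cl` gives 10 nM. Compound 3 `COc1cccc(C(=O)NCc2ccc(CNS(=O)(=O)c3ccc(C)cc3)cc2)c1` gives 10 nM.

Compound 2 stands level with compound 3 at the digits reported; together they give the lowest numbers of the three, while compound 1 sits far higher. Compound 4 `O=C(NCc1ccc(CNS(=O)(=O)c2ccccc2)cc1)c1cccc(F)c1` has not been measured in this assay. It differs from compound 2 in one place: 3-fluorophenyl in place of 2-chlorophenyl on a carbonyl carbon.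

Among the measured compounds shown here, one measured step touches the same position, the aryl group on the carbonyl carbon. That step, a 100-fold lower number from compound 1 to compound 3 (2.00 log units; beyond the scatter), was large, so this assay can respond strongly to what sits on that ring. Yet compound 3, which carries a group substituted in the 3-position of the phenyl like the one entering compound 4, gives the same low number as compound 2. With two different aryl groups both at the low end, there is no reason from these data to expect a large step in either direction from compound 2 to compound 4. A modest shift, within or just beyond the scatter, is the expectation, a 2.0-fold higher number from compound 2 to compound 4 (0.30 log units; within the scatter). For compound 4 the estimate is 20 nM, in the range 5 nM to 100 nM.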

Compound 4, effective concentration (reported as EC, without a stated level of effect): 100 nM
Beside the measured number, compound 4's estimate is 5.0-fold (0.70 log units) below it; low and high end bracket the measured number.
By their numbers in this assay, from the lowest: compounds 2 and 3 (each within the scatter of the next); then compound 4; then compound 1.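

Among the compounds shown here, the exchange of 2-chlorophenyl for 3-fluorophenyl on a carbonyl carbon gives a 10-fold higher number from compound 2 to compound 4 (1.00 log units; beyond the scatter) in this assay and shows that this position also responds on the remainder shared by compound 2 and compound 4, whereas the only earlier step here, a 100-fold lower number from compound 1 to compound 3 (2.00 log units; beyond the scatter), was read on a different remainder and ran towards a lower number. The new step is modest but beyond the scatter, and it appears even though the two groups match in heavy-atom count, have no hydrogen-bond donors or acceptors and carry no net charge, so those counted features do not separate them. Nothing available accounts for the step.

The change swaps the halogen and its place on the ring in a single move, so the compounds shown leave open whether the chlorine, the fluorine or the place each holds goes with the higher number for compound 4. Going by these compounds, how a phenyl group without a halogen, or one carrying an amine or a carboxylic acid, would read on this carbonyl carbon also remains open.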